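The source may hold more compounds than are shown below. What is called first, only, known or untested is meant among the compounds shown, and "the series" means these compounds.

Measured so far in a functional assay on RAW cells (Mus musculus) for inhibition, with a stated time of 24 h; on this read-out lower numbers stand for stronger inhibition and higher numbers for weaker inhibition:

Compound 1, `COc1ccc(OC)c(C(=O)/C=C/c2ccco2)c1`, gives 5700 nM.
Compound 2, `COc1ccc(OC)c(C(=O)/C=C/c2cccs2)c1`, gives only a limit of the assay, > 10000 nM.
Compound 3, `COc1ccc(OC)c(C(=O)/C=C/c2ccc(C)o2)c1`, likewise gives only a limit of the assay, > 10000 nM.

All three share one core and differ only in the ring carried on the double-bonded chain. Compound 3 therefore stands at the edge of what this assay reports: its value is a limit, not a number, and the same is true of compound 2, so the limit of > 10000 nM in this assay, at which 2 of the 3 values shown sit, describes two of the three results. The step of an at least 1.7-fold higher number from compound 1 to compound 3 (0.24 log units; that floor lies within the scatter) is read against a limit as well, and a step that the two limits leave unreadable from compound 2 to compound 3 cannot be read at all.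

Compound 4, `COc1ccc(OC)c(C(=O)/C=C/c2occc2Br)c1`, is not yet measured. The change from compound 3 is 3-bromofuran-2-yl in place of 5-methylfuran-2-yl on a double-bonded chain carbon bound to a double-bonded chain carbon. Within the data shown here, since compound 3 itself sits at a limit, the size of the step to compound 4 can only be set from below; the one readable-ish step, an at least 1.7-fold higher number from compound 1 to compound 3 (0.24 log units; that floor lies within the scatter), says that adding a methyl to the furan of compound 1 pushed the number up into the limit. Taking the methyl away again and placing a bromine elsewhere on the furan is expected to bring the number back toward that of compound 1, so a downward step an at least 1.2-fold lower number from compound 3 to compound 4 (0.09 log units; that floor lies within the scatter) is expected. Compound 4 is therefore estimated at 8000 nM, within 3000 nM to 30000 nM.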

Compound 4, half-maximal inhibitory concentration: 12800 nM
Compound 4: middle estimate off by 1.6-fold (0.20 log units), on the low side, within the range that was stated.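

Among these compounds, compound 4 gives a number rather than a limit in this assay, so a group added to the furan of compound 1 can be sized for the first time: adding a bromine there gives a 2.2-fold higher number from compound 1 to compound 4 (0.35 log units; beyond the scatter). The earlier changes to this ring gave only floors within the scatter or no readable size, so this is the first ring change shown to weaken inhibition by more than the scatter, although the loss is modest and a measurable value remains. The steps to compound 4 from compound 2 and from compound 3 cannot be read, since each of those two compounds gives only a limit: the limit of > 10000 nM in this assay, at which 2 of the 4 values shown sit.

The compounds shown leave open whether this rise is particular to bromine or would also follow from another group at this place on the furan, such as chlorine, a methoxy group or an amine. They also leave open whether 3-bromofuran-2-yl truly differs from 5-methylfuran-2-yl, and whether any change to this ring could give a lower number than compound 1 does.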